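Stability at the chain carbon: phenyl for hydrogen

The source may hold more compounds than are shown below. What is called first, only, known or untested is meant among the compounds shown, and "the series" means these compounds.

Of the compounds shown here, three of the shared core have numbers so far. Compound 1 `CC(C)(C)C1=C(C(=O)O)N2C(=O)[C@H](CO)[C@H]2O1` gives 5 h in an ADME assay, in phosphate buffer, at 28 degrees C, at pH 7.0; a lower number here means that the compound disappears faster, a higher number that the compound lasts longer. Compound 2 `CC(C)(C)C1=C(C(=O)O)N2C(=O)[C@H](CO)[C@@H]2O1` gives 2.4 h in this assay, the lowest of the three, and the step of a 2.1-fold lower number from compound 1 to compound 2 (0.32 log units; beyond the scatter) goes with a change of configuration alone (the fact that compounds 1 and 2 differ only in the configuration as drawn). Compound 3 `CC(C)(C)C1=C(C(=O)O)N2C(=O)[C@H]([C@H](O)CCc3ccncc3)[C@@H]2O1` gives 7.1 h in this assay, reached by the step of a 3.0-fold higher number from compound 2 to compound 3 (0.47 log units; beyond the scatter).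

Compound 4 `CC(C)(C)C1=C(C(=O)O)N2C(=O)[C@H]([C@@H](O)c3ccccc3)[C@@H]2O1` has not yet been measured. Its change from compound 2 is phenyl in place of hydrogen on a saturated chain carbon bound to an oxygen on a saturated carbon and a saturated ring carbon. Of the measured steps, the step of a 3.0-fold higher number from compound 2 to compound 3 (0.47 log units; beyond the scatter) is the one that bears on it: that step too puts a group in place of hydrogen on the same chain carbon, and it was modest, beyond the scatter and upward. A step of similar kind is therefore expected for compound 4, a 2.1-fold higher number from compound 2 to compound 4 (0.32 log units; beyond the scatter), upward and modest, though a phenyl is not a 2-(pyridin-4-yl)ethyl and the size may differ. The estimate for compound 4 in this assay is 5 h, with a range from 2.5 h to 10 h.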

Compound 4, half-life: 2.2 h
Compound 4: the middle estimate sits 2.3-fold (0.36 log units) above what was measured, outside the stated range (below it).
By their numbers in this assay, from the lowest: compounds 4 and 2 (each within the scatter of the next); then compounds 1 and 3 (each within the scatter of the next).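

In this assay, phenyl in place of hydrogen on the chain carbon gives a 1.1-fold lower number from compound 2 to compound 4 (0.04 log units; within the scatter) and so does not go with a longer half-life. The upward step a 3.0-fold higher number from compound 2 to compound 3 (0.47 log units; beyond the scatter) therefore does not hold for every group in place of hydrogen at this carbon: it is seen with 2-(pyridin-4-yl)ethyl, and compound 4 goes against any broader reading. Nothing given here accounts for the different outcomes with these two groups.

Open, from the compounds shown here alone, is whether the step seen with compound 3 goes with the pyridine ring or with the ethyl link, which 2-phenylethyl or pyridin-4-yl on the same chain carbon would help to separate. Also open, going by these compounds, is how an amine or a carboxylic acid at the end of a longer chain would behave at this position.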